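Alkyl variation on the carbamoyl arm of the shared core

The source may report more compounds than this note shows. Statements on the series, on what has been measured and on what is new or still open speak of the compounds shown alone.

Measured so far:
compound 1 `CCCNS(=O)(=O)c1ccc(Nc2ncc3c(n2)N(C2CCCC2)[C@H](CC)C(=O)N3C)cc1`: 2100 nM
compound 2 `CC[C@@H]1C(=O)N(C)c2cnc(-n3ccc4cc(F)ccc43)nc2N1C1CCCC1`: 46500 nM
compound 3 `CC[C@@H]1C(=O)N(C)c2cnc(-n3ccc4cc(C(=O)NC(C)C)ccc43)nc2N1C1CCCC1`: 1840 nM

In a functional assay on NCI-H1975 cells (Homo sapiens) for antiproliferative activity, read by CCK-8 assay, with a stated time of 72 h (on this read-out lower numbers stand for stronger inhibition of growth and higher numbers for weaker inhibition of growth), compound 3 gives the lowest of the three numbers shown. Compound 1 sits within the scatter of it, so no order between compound 3 and compound 1 can be claimed. Going by the values given here, compound 2 stands furthest away: the single measured step, a 25-fold lower number from compound 2 to compound 3 (1.40 log units; beyond the scatter), is the only change recorded so far, and it concerns the appearance of the carbamoyl group rather than the alkyl on its nitrogen.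

Compound 4 `CCCCNC(=O)c1ccc2c(ccn2-c2ncc3c(n2)N(C2CCCC2)[C@H](CC)C(=O)N3C)c1` keeps that carbamoyl group and alters only its alkyl: butyl in place of isopropyl on an amide-type nitrogen. Among the compounds with values here, no measured pair varies the alkyl on this amide-type nitrogen, so nothing recorded bears directly on the step from compound 3 to compound 4. The structures differ by one carbon and a change from branched to straight chain, with no change in donors or acceptors. The expectation is therefore a step within the scatter, a 1.0-fold lower number from compound 3 to compound 4 (0.01 log units; within the scatter), with no direction favoured. For compound 4 the estimated value in this assay is 1800 nM, with a range from 800 nM to 4000 nM.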

Compound 4, concentration for 50% growth inhibition: 990 nM
The estimate for compound 4 lay 1.8-fold (0.26 log units) above the measured number; the measured number falls inside the stated range.
By their numbers in this assay, from the lowest: compounds 4, 3 and 1 (each within the scatter of the next, the first and the last beyond it); then compound 2.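

In this assay, butyl in place of isopropyl on the amide-type nitrogen gives a step within the scatter (a 1.9-fold lower number from compound 3 to compound 4 (0.27 log units; within the scatter)), so this first variation of the alkyl does not separate a straight chain from a branched one at this position. The large separation from the fluoro compound holds with the butylcarbamoyl group as well (a 47-fold lower number from compound 2 to compound 4 (1.67 log units; beyond the scatter)), so it now rests on two carbamoyl compounds, which differ in their alkyl, rather than on compound 3 alone. Nothing shown gives a reason for either step.

Open, as far as these compounds go, is whether a longer chain such as octyl, a ring such as cyclohexyl, or a terminal amine on the chain would move the number beyond the scatter. Also open, from the compounds shown here alone, is how a dimethylcarbamoyl group, which lacks the amide hydrogen, would compare.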